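Methyl on the saturated ring: from compound 3 to compound 4

The source may hold more compounds than are shown below. What is called first, only, known or untested is meant among the compounds shown, and "the series" means these compounds.

Measured values, all from a functional assay on HepG2 cells (Homo sapiens) for antiproliferative activity, read by MTT assay, with a stated time of 72 h; a higher number here means a weaker inhibitor, a lower number a stronger inhibitor:
Compound 1, `COc1cc2c(Nc3ccc(C#N)cc3)ncnc2cc1OCCCN1CCCCC1`, gives 20700 nM.
Compound 2, `COc1cc2c(Nc3ccc(C#N)cc3)ncnc2cc1OCCCN1CCC(C)CC1`, gives 32100 nM.
Compound 3, `COc1cc2c(Nc3cccc(C#N)c3)ncnc2cc1OCCCN1CCCCC1`, gives 29500 nM.

Compound 2 differs from compound 1 by methyl in place of hydrogen on a saturated ring carbon, and this step gave a 1.6-fold higher number from compound 1 to compound 2 (0.19 log units; within the scatter). The cores of compound 1 and compound 3 differ by 3-cyanophenyl in place of 4-cyanophenyl on a nitrogen on an aromatic ring, with a step of a 1.4-fold higher number from compound 1 to compound 3 (0.15 log units; within the scatter). Compound 4, `COc1cc2c(Nc3cccc(C#N)c3)ncnc2cc1OCCCN1CCC(C)CC1`, has no value yet in this assay. It differs from compound 3 by methyl in place of hydrogen on a saturated ring carbon, the same change at the same place as between compound 1 and compound 2. The expected step is a 1.5-fold higher number from compound 3 to compound 4 (0.18 log units; within the scatter), and it rests on the earlier step of a 1.6-fold higher number from compound 1 to compound 2 (0.19 log units; within the scatter), itself within the scatter. In this assay compound 4 is expected to give 45000 nM, between 20000 nM and 100000 nM.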

Compound 4, half-maximal inhibitory concentration: 18200 nM
Beside the measured number, compound 4's estimate is 2.5-fold (0.39 log units) above it; measured number outside the range, below it.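

In this assay the methyl change on the core of compound 3 reads a 1.6-fold lower number from compound 3 to compound 4 (0.21 log units; within the scatter), and set beside the same change on the core of compound 1 it gives no difference that can be told from scatter: the same change on two cores in this assay, a 1.6-fold higher number (0.19 log units; within the scatter) from compound 1 to compound 2 and a 1.6-fold lower number (0.21 log units; within the scatter) from compound 3 to compound 4, 2.5-fold (0.40 log units) apart, within the scatter of two such steps

The change to 3-cyanophenyl with the methyl in place reads a 1.8-fold lower number from compound 2 to compound 4 (0.25 log units; within the scatter), and the comparison comes out the same way: the same change on two cores in this assay, a 1.4-fold higher number (0.15 log units; within the scatter) from compound 1 to compound 3 and a 1.8-fold lower number (0.25 log units; within the scatter) from compound 2 to compound 4, 2.5-fold (0.40 log units) apart, within the scatter of two such steps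

So neither change is shown to depend on the core, but with every step within the scatter, neither is shown to have a real effect or a size that would carry to a further core.

On these data alone, whether a morpholine or a piperazine in place of the piperidine, or a longer chain, would give a step beyond the scatter stays open. Also open, as far as these compounds go, is how the methyl change behaves with a chlorine in place of the nitrile.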